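Replacing the aryl amine of compound 1 with 3-chlorobenzyl

The source may report more compounds than this note shows. Statements on the series, on what has been measured and on what is new or still open speak of the compounds shown alone.

Measured in a functional assay on BT-474 cells (Homo sapiens) for inhibition, read by fluorescence, with a stated time of 72 h; on this read-out lower numbers stand for stronger inhibition of growth and higher numbers for weaker inhibition of growth:
- compound 1 `COc1ccc(Nc2nc(N[C@H]3CC[C@H](N)CC3)nc3c2ncn3CCC(C)C)c(OC)c1`: 7900 nM
- compound 2 `N[C@H]1CC[C@H](Nc2nc(Nc3ccc(Cl)cc3)c3ncn(C4CCCCC4)c3n2)CC1`: 4100 nM
- compound 3 `COc1ccc(Cn2cnc3c(Nc4cccc(Cl)c4)nc(N[C@H]4CC[C@H](N)CC4)nc32)cc1`: 8200 nM

Compound 1, at 7900 nM, lies within the scatter of both compound 2 and compound 3, so the numbers give it no meaningful rank among the three. All of them show weak growth inhibition on this scale, in the micromolar range.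

The next compound is compound 4 `CC(C)CCn1cnc2c(NCc3cccc(Cl)c3)nc(N[C@H]3CC[C@H](N)CC3)nc21`. It keeps the core of compound 1 and its other substituents, but has 3-chlorobenzyl in place of 2,4-dimethoxyphenyl on a nitrogen on an aromatic ring. Cut one bond further out, the same difference reads (2,4-dimethoxyphenyl)amino to (3-chlorobenzyl)amino.

For the measured compounds named here, no two measured compounds differ in one place only, so the size of this change in this assay has no direct precedent. Going by the values given here, the only guide is the narrow spread of the measured values, from compound 2 at 4100 nM to compound 3 at 8200 nM, even though these compounds differ in more than one place. On that basis, no change beyond the scatter is expected, and the estimated step is a 1.3-fold lower number from compound 1 to compound 4 (0.12 log units; within the scatter). For compound 4 the expected value is 6000 nM, with an estimated range of 2000 nM to 18000 nM.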

Compound 4, concentration for 50% growth inhibition: 6600 nM
Compound 4: the middle estimate sits 1.1-fold (0.04 log units) below what was measured, and the stated range covers the measured number.
By their numbers in this assay, from the lowest: compounds 2, 4, 1 and 3 (each within the scatter of the next).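

In this assay, for the compounds shown here, the exchange of 2,4-dimethoxyphenyl for 3-chlorobenzyl on a nitrogen on an aromatic ring gives a 1.2-fold lower number from compound 1 to compound 4 (0.08 log units; within the scatter), the first reading of a single change. At this position, the step from one group to the other therefore leaves the growth read-out within the scatter, even though the leaving group's 2 hydrogen-bond acceptors are lost and a chlorine enters. As these differences arrive together, a single step cannot separate them or show whether their contributions offset one another, and no supporting measurement explains the result.

Still open is whether any group on this nitrogen can move the number beyond the scatter, as the groups shown here each carry one six-membered aromatic ring; a hexyl chain, a pyridine ring or a phenyl ring bearing a carboxylic acid would probe a wider range of structures. Also open, from the compounds shown here alone, is whether the same exchange stays this small when the other substituents on the shared core are different.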